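The source may hold more compounds than are shown below. What is called first, only, known or untested is meant among the compounds shown, and "the series" means these compounds.

Of the compounds shown here, three built on one shared core have been tested in an ADME assay on HEK293 cells (Homo sapiens) for cytotoxicity, read by MTT assay, with a stated time of 48 h (a lower number here means a stronger inhibitor, a higher number a weaker inhibitor), and a fourth awaits its result. Compound 1 `Cc1cc(NC(=O)c2ccc(Cl)cc2)ccc1NS(C)(=O)=O` gives 50300 nM. Compound 2 `Cc1cc(NC(=O)c2ccc(C#N)cc2)ccc1NS(C)(=O)=O` carries the change cyano in place of chloro on an aromatic carbon relative to compound 1, and in this assay compound 2 gives 43500 nM. The step is a 1.2-fold lower number from compound 1 to compound 2 (0.06 log units; within the scatter), so these two numbers cannot be told apart. The core of compound 3 `CS(=O)(=O)Nc1ccc(NC(=O)c2ccc(Cl)cc2)cc1F` differs from the core of compound 1 by fluoro in place of methyl on an aromatic carbon; in this assay compound 3 gives 216000 nM, and the step is a 4.3-fold higher number from compound 1 to compound 3 (0.63 log units; beyond the scatter), a modest shift toward weaker inhibition.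

Compound 4 `CS(=O)(=O)Nc1ccc(NC(=O)c2ccc(C#N)cc2)cc1F` has not yet been measured. It stands to compound 3 exactly as compound 2 stands to compound 1, differing by cyano in place of chloro on an aromatic carbon; the place described for both changes is the same word for word, so this is the same change made on the other core. Among the four compounds this change occurs twice in all.

The step expected in this assay is a 1.2-fold lower number from compound 3 to compound 4 (0.07 log units; within the scatter), which rests on the earlier step of the same change being a 1.2-fold lower number from compound 1 to compound 2 (0.06 log units; within the scatter), a shift within the scatter. Within the data shown here, with only one earlier example, the expectation stays close to the starting number. Compound 4 is therefore estimated at 185000 nM, with a plausible range from 90000 nM to 380000 nM.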

Compound 4, half-maximal inhibitory concentration: > 250000 nM
Compound 4: only a limit was reported; the forecaster's own chance of this, stated with the estimate: 20%; at least 1.3-fold (0.13 log units) between middle value and limit.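

In this assay compound 4 reaches only a limit of the assay, > 250000 nM, which is a boundary and not a true number. Carried onto the core of compound 3, cyano in place of chloro gives an at least 1.1-fold higher number from compound 3 to compound 4 (0.06 log units; that floor lies within the scatter), so the result fits a change that carries over with little effect but does not prove it, and a larger effect on this core also remains possible: the same change on two cores in this assay, a 1.2-fold lower number (0.06 log units; within the scatter) from compound 1 to compound 2 and an at least 1.1-fold higher number (0.06 log units; that floor lies within the scatter) from compound 3 to compound 4; the limit leaves it open whether they differ. Among these compounds, the fluoro in place of methyl change gives an at least 5.7-fold higher number from compound 2 to compound 4 (0.75 log units; beyond the scatter), which points the same way as on the first pair of compounds, although its true size on this pair stays unknown: the same change on two cores in this assay, a 4.3-fold higher number (0.63 log units; beyond the scatter) from compound 1 to compound 3 and an at least 5.7-fold higher number (0.75 log units; beyond the scatter) from compound 2 to compound 4; the limit leaves it open whether they differ.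

What the compounds shown leave open is how far the true number of compound 4 lies past the limit, and therefore whether either change has the same size on both cores. They also leave open how this assay would respond to an amine or a carboxylic acid in place of chloro or cyano, or to a longer chain in place of methyl or fluoro.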